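Oxazole to Imidazole: One Ring Swap on a Saturated Carbon

The source may report more compounds than this note shows. Statements on the series, on what has been measured and on what is new or still open speak of the compounds shown alone.

Measured compounds:
compound 1 `CC#CCn1c(N2CCC[C@@H](N)C2)nc2c1c(=O)n(CCCN1CCC(c3ncc(-c4ccccc4)o3)CC1)c(=O)n2C`: 830 nM
compound 2 `CC#CCn1c(N2CCC[C@@H](N)C2)nc2c1c(=O)n(CCCN1CCN(c3noc(-c4ccccc4)n3)CC1)c(=O)n2C`: 1450 nM

Both compounds were tested in a functional assay on HEK293 cells for agonist activity at Glucose-dependent insulinotropic receptor (Homo sapiens), read by a luciferase reporter; on this read-out higher numbers stand for an effect only at larger amounts of compound and lower numbers for an effect already at smaller amounts. Compound 1 gives 830 nM, and compound 2 gives 1450 nM. The two numbers lie within the usual scatter of each other, so on this assay neither compound can be set apart from the other; compound 1 simply carries the smaller of the two values.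

Compound 3 `CC#CCn1c(N2CCC[C@@H](N)C2)nc2c1c(=O)n(CCCN1CCC(c3nc(-c4ccccc4)c[nH]3)CC1)c(=O)n2C` has not yet been measured. Compared with compound 1 it differs in one place: 4-phenyl-1H-imidazol-2-yl in place of 5-phenyl-1,3-oxazol-2-yl on a saturated ring carbon. The two groups are the same size and keep the same shape of a five-membered aromatic ring carrying a phenyl ring; what changes is the count of donors and acceptors.

Among the measured compounds shown here, no pair of measured compounds differing in just one place is known, so there is no measured step to lean on. The change looks small, and the step from compound 1 to compound 3 is expected to stay within the scatter, as a 1.2-fold higher number from compound 1 to compound 3 (0.08 log units; within the scatter). Compound 3 is therefore expected to give about 1000 nM in this assay. The expected range for compound 3 runs from 300 nM to 3500 nM.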

Compound 3, half-maximal effective concentration: 600 nM
The estimate for compound 3 lay 1.7-fold (0.22 log units) above the measured number; measured number inside the range.
By their numbers in this assay, from the lowest: compounds 3, 1 and 2 (each within the scatter of the next, the first and the last beyond it).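

In this assay, among the compounds shown here, 4-phenyl-1H-imidazol-2-yl in place of 5-phenyl-1,3-oxazol-2-yl on the saturated ring carbon gives a 1.4-fold lower number from compound 1 to compound 3 (0.14 log units; within the scatter), the first step in this set that changes only one place. The swap goes from a group with 0 hydrogen-bond donors and 2 acceptors to one with 1 donor and 1 acceptor, yet compound 1 and compound 3 cannot be told apart on this read-out, so at this position the two rings are interchangeable as far as this assay can show. Nothing measured here explains that outcome.

The compounds shown leave open whether the hydrogen on the imidazole nitrogen plays any part, which a methyl group in place of that hydrogen could test. Also open, on these data alone, is how a carboxylic acid or a plain amine on that same saturated ring carbon, with no phenyl-bearing five-membered ring at all, would read in this assay.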